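The compounds below may be only part of what the source reports. "The series", "measured", "known", "first", "only" and "open" are said of these compounds alone.

Measured compounds and values:

compound 1 `CC(C)(C)n1cc2c(n1)C(=O)CC1(CCN(C(=O)c3cc(-c4ccccc4)nc4ccccc34)CC1)O2` — in a functional assay on MDA-MB-231 cells (Homo sapiens) for inhibition, read by MTT assay, with a stated time of 72 h (on this read-out lower numbers stand for stronger inhibition and higher numbers for weaker inhibition), compound 1 gives > 10000 nM, which is a limit of the assay.
compound 2 `CC(C)(C)n1cc2c(n1)C(=O)CC1(CCN(C(=O)c3cc(-c4ccc(Cl)cc4)nc4ccccc34)CC1)O2` — in this assay compound 2 gives > 10000 nM, which is a limit of the assay.

Compound 2 therefore stands only at a limit, with no number of its own. The step that the two limits leave unreadable from compound 1 to compound 2, chloro in place of hydrogen on an aromatic carbon, is not readable because of the limit of > 10000 nM in this assay, at which 2 of the 2 values shown sit; both values sit at that limit.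

Compound 3 `CC(C)(C)n1cc2c(n1)C(=O)CC1(CCN(C(=O)c3cc(Cl)nc4ccccc34)CC1)O2` differs from compound 2 by chloro in place of 4-chlorophenyl on an aromatic carbon. Among the measured compounds shown here, the only measured step is the one from compound 1 to compound 2, and it bears on compound 3 only in that neither end of it gives a number; it offers no reading of size or direction. What the shared core shows so far is two limits, so the expectation is that compound 3 will also sit at or past the limit in this assay, with no step beyond the scatter resolvable. The estimated step that the limit leaves unreadable from compound 2 to compound 3 is expected to be essentially none. Compound 3 is estimated at 20000 nM, within 7000 nM to 60000 nM.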

Compound 3, half-maximal inhibitory concentration: 9220 nM
Beside the measured number, compound 3's estimate is 2.2-fold (0.34 log units) above it; low and high end bracket the measured number.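

Among the compounds shown here, at the aromatic carbon next to the ring nitrogen, chloro in place of 4-chlorophenyl gives the first value that is a number and not a limit: in this assay compound 3 gives 9220 nM. Against the earlier compounds this can be read only as a floor, an at least 1.0-fold lower number from compound 2 to compound 3 (0.03 log units; that floor lies within the scatter), and with chloro in place of phenyl as an at least 1.0-fold lower number from compound 1 to compound 3 (0.03 log units; that floor lies within the scatter), so neither step shows a change beyond the scatter, and the true size of each stays unknown. The aromatic ring at this position is therefore not needed for a readable value in this series, while the two compounds that carry an aryl group there give no number with which to size the change: the limit of > 10000 nM in this assay, at which 2 of the 3 values shown sit.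

As far as these compounds go, it remains open whether an amine such as morpholine, a carboxylic acid or a short alkyl chain at this carbon would give a number that stands clearly apart from that of compound 3. From the compounds shown here alone, with a single numerical value, it is also open whether any change at this position can move the read-out by more than the scatter.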